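The compounds below may be only part of what the source reports. "The series", "measured", "known", "first", "only" and "open" are said of these compounds alone.

Compound 1 `Fc1cccc(-c2nc(Nc3ccccc3)c3cc(F)ccc3n2)c1` is the starting point. In a functional assay on MCF7 cells (Homo sapiens) for cytotoxicity, read by MTT assay, with a stated time of 48 h (a higher number here means a weaker inhibitor, a lower number a stronger inhibitor), compound 1 gives 49700 nM. Compound 2 `Fc1cccc(-c2nc(Nc3ccc(Cl)cc3)c3cc(F)ccc3n2)c1` carries one change relative to compound 1: chloro in place of hydrogen on an aromatic carbon. In this assay compound 2 reaches only > 50000 nM, which is a limit of the assay and not a number. The step of a number no lower from compound 1 to compound 2 (the limit leaves the size open) is therefore of unreadable size, because of the limit of > 50000 nM in this assay, at which 1 of the 2 values shown sits.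

Compound 3 `Fc1cccc(-c2nc(Nc3cccc(Cl)c3)c3cc(F)ccc3n2)c1` differs from compound 2 by 3-chlorophenyl in place of 4-chlorophenyl on a nitrogen on an aromatic ring. Going by the values given here, no measured step involves moving a chloro group between positions, so the one step known, from compound 1 to compound 2, does not bear directly on this change. Among the compounds with values here, with compound 2 sitting at the limit and no step of readable size to draw on, no movement beyond the scatter is expected in this assay. Compound 3 is accordingly estimated at 50000 nM, within 25000 nM to 100000 nM. That estimate means an expected step of a number no higher from compound 2 to compound 3 (the limit leaves the size open).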

Compound 3, half-maximal inhibitory concentration: > 50000 nM
Compound 3: only a limit was reported (the forecaster's own chance of this, stated with the estimate: 50%); the middle value lies on the limit itself.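

In this assay the 3-chlorophenyl group on this nitrogen, like the 4-chlorophenyl group, gives a number no lower from compound 1 to compound 3 (the limit leaves the size open). Moving the chloro group therefore brings no measurable gain in strength, and compound 2 and compound 3 cannot be ranked against each other. The steps to compound 3 from compound 2 and from compound 1 cannot be read in size: the limit of > 50000 nM in this assay, at which 2 of the 3 values shown sit.

On these data alone, whether the two chloro placements differ at all remains open, since any difference would lie beyond what this limit can show. Also open, as far as these compounds go, is whether a different group on this ring, such as an amine or a carboxylic acid, would give a lower number than compound 1.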